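A Nitrile Replaces Two Chlorines: Expected Potency Shift

The source may report more compounds than this note shows. Statements on the series, on what has been measured and on what is new or still open speak of the compounds shown alone.

Compound 1 `O=C(/C=C/c1ccccc1)Nc1cc2ncnc(Nc3ccc(F)c(Cl)c3)c2s1` and compound 2 `O=C(/C=C/c1ccccc1)Nc1cc2ncnc(Nc3cc(Cl)cc(Cl)c3)c2s1` share one core and differ only in the ring attached to a nitrogen on an aromatic ring. In a functional assay on MDA-MB-231 cells (Homo sapiens) for antiproliferative activity, read by MTT assay, with a stated time of 48 h (on this read-out lower numbers stand for stronger inhibition and higher numbers for weaker inhibition), compound 1 gives 2100 nM, while in this assay compound 2 gives 1000 nM. The step of a 2.1-fold lower number from compound 1 to compound 2 (0.32 log units; beyond the scatter) shows that rearranging the halogens on that ring moves the number by a modest but real amount. Compound 2 therefore stands lowest of the two numbers measured, with compound 1 the nearest.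

Compound 3 `N#Cc1cccc(Nc2ncnc3cc(NC(=O)/C=C/c4ccccc4)sc23)c1` carries the change (3-cyanophenyl in place of 3,5-dichlorophenyl on a nitrogen on an aromatic ring). Among the measured compounds shown here, no measured pair exchanges chlorines for a nitrile, so the only guide is the step of a 2.1-fold lower number from compound 1 to compound 2 (0.32 log units; beyond the scatter), in which a change of substituents on this same ring gave a modest shift. Because that step a 2.1-fold lower number from compound 1 to compound 2 (0.32 log units; beyond the scatter) was modest, a shift of about that size is expected here too, and with a hydrogen-bond acceptor entering where none was, a somewhat higher number is expected, a 1.6-fold higher number from compound 2 to compound 3 (0.20 log units; within the scatter). Compound 3 is estimated at 1600 nM in this assay, with an expected range from 500 nM to 5000 nM.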

Compound 3, half-maximal inhibitory concentration: 1040 nM
Beside the measured number, compound 3's estimate is 1.5-fold (0.19 log units) above it; low and high end bracket the measured number.
By their numbers in this assay, from the lowest: compounds 2 and 3 (each within the scatter of the next); then compound 1.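

The exchange of 3,5-dichlorophenyl for 3-cyanophenyl gives a 1.0-fold higher number from compound 2 to compound 3 (0.02 log units; within the scatter) in this assay and so cannot be told apart from the scatter, even though the entering ring carries a hydrogen-bond acceptor and the leaving ring carries none. Set against 3-chloro-4-fluorophenyl, the same nitrile-bearing ring gives a 2.0-fold lower number from compound 1 to compound 3 (0.31 log units; beyond the scatter) and this shows that, among the three compounds shown, a ring on this nitrogen can reach the lower numbers without carrying any halogen. Nothing available here gives a measured reason why the nitrile-bearing ring and the dichlorinated ring read alike.

The compounds shown leave open whether the nitrile itself contributes anything, since a plain phenyl ring would be needed to settle that, and how a ring bearing an amine, a methoxy group or a carboxylic acid would read at this position. Going by these compounds, it also remains open whether the match between 3-cyanophenyl and 3,5-dichlorophenyl would hold in other cell lines or with a different group on the amide side of the shared core.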